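The source may report more compounds than this note shows. Statements on the series, on what has been measured and on what is new or still open speak of the compounds shown alone.

Measured so far in an assay on cells for inhibition of Amine oxidase [flavin-containing] A (Homo sapiens), read by fluorescence, spectrophotometry and Amplex Red, with stated times of 60 min and 30 min; on this read-out lower numbers stand for stronger inhibition and higher numbers for weaker inhibition:
compound 1 `CN(C)CCC(=O)c1cc2ccc(O)cc2oc1=O` — 110000 nM
compound 2 `CCN(CC)CCC(=O)c1cc2ccc(O)cc2oc1=O` — 90000 nM

Compound 2 gives the lowest of the two numbers, with compound 1 within the scatter of it. Compound 3 `O=C(CCN1CCCC1)c1cc2ccc(O)cc2oc1=O` differs from compound 2 by pyrrolidin-1-yl in place of diethylamino on a saturated chain carbon, two bonds along the chain from a carbonyl carbon. Among the compounds with values here, the only step on record, a 1.2-fold lower number from compound 1 to compound 2 (0.09 log units; within the scatter), also swaps one amino group for another at the same place and lay within the scatter; no measured step trades an open-chain amine for a ring. The expected step of no change at the digits printed from compound 2 to compound 3 (within the scatter) is therefore small, with no direction claimed beyond the scatter. Compound 3 is estimated at 90000 nM, within 40000 nM to 200000 nM.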

Compound 3, half-maximal inhibitory concentration: > 200000 nM
Compound 3 was reported as a limit; the forecaster's own chance of this, stated with the estimate: 15%; middle value at least 2.2-fold (0.34 log units) from the limit.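

In this assay, within the data shown here, pyrrolidin-1-yl on a saturated chain carbon, two bonds along the chain from a carbonyl carbon, gives an at least 2.2-fold higher number from compound 2 to compound 3 (0.34 log units; beyond the scatter) as the first step at this place beyond the scatter, so a ring here is not interchangeable with diethylamino. Against dimethylamino the comparison is less firm, with an at least 1.8-fold higher number from compound 1 to compound 3 (0.25 log units; that floor lies within the scatter) as its reading. Compound 3 gives > 200000 nM, which is a limit: the limit of > 200000 nM in this assay, at which 1 of the 3 values shown sits.

Going by these compounds, how far the true steps extend past that limit stays open. Also open, on these data alone, is whether piperidin-1-yl or morpholin-4-yl at this place would behave like pyrrolidin-1-yl.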